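Phenyl in Place of Cyclohexyl on a Carbonyl Carbon

The source may report more compounds than this note shows. Statements on the series, on what has been measured and on what is new or still open speak of the compounds shown alone.

Three compounds of one series have been measured in a physicochemical assay for lipophilicity, read by HPLC, measured as chromatographic lipophilicity, at pH 7.4; on this read-out lower numbers stand for lower lipophilicity and higher numbers for higher lipophilicity:

compound 1 `O=C(C1CCCCC1)N1CCC(C(=O)N2N=CCC2c2ccccc2)CC1` gives 5.4
compound 2 `O=C(c1cscn1)N1CCC(C(=O)N2N=CC[C@H]2c2ccccc2)CC1` gives 3
compound 3 `Cc1nnc(N2CCC(C(=O)N3N=CC[C@H]3c3cc(F)cc(F)c3)CC2)o1` gives 3.6

Compound 1 stands highest of the three numbers. The nearest to it is compound 3, whose number lies lower by a margin beyond the usual scatter of this assay. The furthest is compound 2, whose number lies lower still, again beyond the scatter. No pair among these three differs in a single place, so no measured step can be read from them; only the values themselves speak.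

The account now turns to compound 4 `O=C(c1ccccc1)N1CCC(C(=O)N2N=CCC2c2ccccc2)CC1`, which has not yet been measured in this assay. It differs from compound 1 in one place: phenyl in place of cyclohexyl on a carbonyl carbon. The group that leaves and the group that enters are each a six-membered ring of carbon only, the one non-aromatic and the other aromatic, carrying no donors, no acceptors and no charge.

Among the measured compounds shown here, since no step of this kind is present among the measured compounds, the size is a matter of expectation. The step from compound 1 to compound 4 is expected to be downward and of moderate size, a number 0.70 log units lower from compound 1 to compound 4 (beyond the scatter), beyond the scatter. For compound 4 the estimated value in this assay is 4.7, with a range from 4.2 to 5.2.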

Compound 4, distribution coefficient: 4.4
Compound 4: the middle estimate sits 0.30 log units above what was measured, and the stated range covers the measured number.
By their numbers in this assay, from the lowest: compound 2; then compound 3; then compound 4; then compound 1.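

With compound 4 the series gains its first step that can be read in this assay: phenyl in place of cyclohexyl on a carbonyl carbon comes out as a number 1.00 log units lower from compound 1 to compound 4 (beyond the scatter). Among the compounds shown here, the earlier compounds could show only that values spread widely, whereas this pair shows that the read-out responds to a change at this one position, even though the group that leaves and the group that enters both have six heavy atoms, all carbon, and neither carries a donor, an acceptor or a net charge; the difference counted between them is that the six-membered ring is non-aromatic in one and aromatic in the other. Nothing at hand offers an explanation for the direction or size of this step.

This remains a single step on a single core, so the compounds shown do not tell whether the same exchange would give a similar step in another member of the series. They also leave open how the read-out would move if an amine, a carboxylic acid or a longer alkyl chain stood on this carbonyl carbon instead of either ring.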